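This account rests on a few compounds, and the source may have more. Where it says the series, first, only, none or still open, it means among the compounds named here.

Measured in a functional assay on K562 cells (Homo sapiens) for antiproliferative activity, read by CellTiter-Glo, with a stated time of 72 h; on this read-out higher numbers stand for an effect only at larger amounts of compound and lower numbers for an effect already at smaller amounts:
compound 1 `CCCCCNc1ncnc2c1ncn2[C@@H]1O[C@H](COS(N)(=O)=O)[C@@H](O)[C@H]1O`: 181 nM
compound 2 `CCCCCCNc1ncnc2c1ncn2[C@@H]1O[C@H](COS(N)(=O)=O)[C@@H](O)[C@H]1O`: 160 nM
compound 3 `CN(Cc1ccco1)c1ncnc2c1ncn2[C@@H]1O[C@H](COS(N)(=O)=O)[C@@H](O)[C@H]1O`: > 1000 nM (a limit)

Compound 3 stands at > 1000 nM, which is a limit of the assay and not a number. The next compound, not yet measured, is compound 4 `NS(=O)(=O)OC[C@H]1O[C@@H](n2cnc3c(NCc4cccs4)ncnc32)[C@H](O)[C@@H]1O`. The change is ((thiophen-2-yl)methyl)amino in place of ((furan-2-yl)methyl)(methyl)amino on an aromatic carbon.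

Among the compounds with values here, two measured steps bear on this change: an at least 5.5-fold higher number from compound 1 to compound 3 (0.74 log units; beyond the scatter) and an at least 6.2-fold higher number from compound 2 to compound 3 (0.79 log units; beyond the scatter). Each exchanges the chain for the ring-bearing group and adds the methyl on the nitrogen in one move, so the data do not separate the two. The step of a 1.1-fold lower number from compound 1 to compound 2 (0.05 log units; within the scatter) stays within the scatter, so compound 1 and compound 2 serve together as one reference.

Compound 4 has no methyl on that nitrogen, as in compound 1 at 181 nM and compound 2 at 160 nM, so a move towards those values is expected in this assay. Within the data shown here, no measured compound combines a five-membered aromatic ring with that unmethylated nitrogen, so the full return is not assumed. The expected change is an at least 2.8-fold lower number from compound 3 to compound 4 (0.45 log units; beyond the scatter), towards a lower number. Compound 4 is estimated at 350 nM, with an expected range from 100 nM to 1000 nM.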

Compound 4, half-maximal effective concentration: 114 nM
For compound 4 the middle estimate is 3.1-fold (0.49 log units) above the measured one; measured number inside the range.
By their numbers in this assay, from the lowest: compounds 4, 2 and 1 (each within the scatter of the next). At a limit, above all of these: compound 3.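

In this assay, the step of an at least 8.7-fold lower number from compound 3 to compound 4 (0.94 log units; beyond the scatter) shows that a group bearing a five-membered aromatic ring on this aromatic carbon need not end at the limit, so the ring alone does not go with the loss seen in compound 3. Against the chains, the steps of a 1.4-fold lower number from compound 2 to compound 4 (0.15 log units; within the scatter) and a 1.6-fold lower number from compound 1 to compound 4 (0.20 log units; within the scatter) put the ((thiophen-2-yl)methyl)amino group on a par with hexylamino and pentylamino, with no order among the three. Compound 3 remains a limit and not a number, so its step gives only a bound: the limit of > 1000 nM in this assay, at which 1 of the 4 values shown sits.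

Still open, as far as these compounds go, is whether the methyl on the nitrogen or the exchange of furan for thiophene carries that step, since both change together; a ((furan-2-yl)methyl)amino group or a ((thiophen-2-yl)methyl)(methyl)amino group on this carbon would separate them. Also open, from the compounds shown here alone, is how a benzylamino group or a longer chain such as octylamino would read in this assay.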